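Replacing Ethoxy with Methylsulfanyl in a Cell Toxicity Test

This account rests on a few compounds, and the source may have more. Where it says the series, first, only, none or still open, it means among the compounds named here.

In a functional assay on HFF cells (Homo sapiens) for cytotoxicity (a higher number here means a weaker inhibitor, a lower number a stronger inhibitor), compound 1 (`CC(=O)OC1C(CBr)OC(n2c(Cl)nc3cc(Cl)c(Cl)cc32)C1OC(C)=O`) gives 32000 nM and compound 2 (`CCOC[C@H]1OC(n2c(Cl)nc3cc(Cl)c(Cl)cc32)[C@H](O)[C@@H]1O`) gives 26000 nM as the only results so far. These two numbers lie within the usual scatter of repeated measurements, so compound 2 cannot be ranked against compound 1. The two compounds also differ in more than one place, which means their results say nothing about any single structural change.

Compound 3 (`CSC[C@H]1OC(n2c(Cl)nc3cc(Cl)c(Cl)cc32)[C@H](O)[C@@H]1O`) has not yet been measured. It differs from compound 2 in one place, and that change is methylsulfanyl in place of ethoxy on a saturated chain carbon bound to a saturated ring carbon in the form of methylsulfanyl in place of ethoxy on a saturated chain carbon bound to a saturated ring carbon. Among the compounds with values here, no measured pair shows what this kind of swap does in this assay so no step beyond the scatter is expected in either direction. The expected change is a 1.1-fold higher number from compound 2 to compound 3 (0.03 log units; within the scatter) and it stays within the scatter. For compound 3 the estimated value is 28000 nM with an expected range from 12000 nM to 70000 nM for this measurement.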

Compound 3, half-maximal inhibitory concentration: 32000 nM
The estimate for compound 3 lay 1.1-fold (0.06 log units) below the measured number; low and high end bracket the measured number.
By their numbers in this assay, from the lowest: compounds 2, 1 and 3 (each within the scatter of the next).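

In this assay, within the data shown here, compounds 2 and 3 give the first comparison that isolates a single structural change, and placing methylsulfanyl in place of ethoxy on a saturated chain carbon bound to a saturated ring carbon gives a 1.2-fold higher number from compound 2 to compound 3 (0.09 log units; within the scatter). This exchange of a group of 3 heavy atoms, with an oxygen, for one of 2 heavy atoms, with a sulfur, therefore produces no readable change in this test, although the hydrogen-bond acceptor count stays the same. No supporting measurement bears on this result, so the data offer no explanation for it.

From the compounds shown here alone, it remains open whether a primary amine, a carboxylic acid or a longer chain such as butoxy at this same place would move the number beyond the scatter, since both groups compared here are small and uncharged. This single pair also cannot show whether the same swap would behave in the same way on a different core, or whether the outcome would hold with the acetyl ester groups of compound 1 on the ring.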